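Restoring the Ring, Losing the Amine: Compound 3 Foreseen

The compounds below may be only part of what the source reports. "The series", "measured", "known", "first", "only" and "open" are said of these compounds alone.

Compound 1 `NC1CCN(c2ccc3cc(NC(=O)CCc4ccc(C(F)(F)F)cc4)ccc3n2)C1`: 12 nM
Compound 2 `CCN(CC)c1ccc2cc(NC(=O)CCc3ccc(C(F)(F)F)cc3)ccc2n1`: 88 nM

Both compounds were tested in an assay on isolated protein for displacement of a labelled ligand from melanin-concentrating hormone receptor 1 (Homo sapiens); on this read-out lower numbers stand for stronger inhibition and higher numbers for weaker inhibition. Compound 2 stands at the higher of the two numbers, weaker than compound 1 by a 7.3-fold higher number from compound 1 to compound 2 (0.87 log units; beyond the scatter), a difference beyond the usual scatter.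

Compound 3 `CC1CCN(c2ccc3cc(NC(=O)CCc4ccc(C(F)(F)F)cc4)ccc3n2)C1` has not been measured. It differs from compound 2 by 3-methylpyrrolidin-1-yl in place of diethylamino on an aromatic carbon. Among the compounds with values here, the only measured step that bears on this change is a 7.3-fold higher number from compound 1 to compound 2 (0.87 log units; beyond the scatter), in which a five-membered ring carrying an amino group gave way to an open-chain diethylamino. Compound 3 brings a five-membered ring back but carries a methyl group where compound 1 had the amino group, so only part of that step is retraced. In this assay compound 3 is therefore expected to give a lower number than compound 2, a step of a 2.5-fold lower number from compound 2 to compound 3 (0.40 log units; beyond the scatter), though likely not reaching compound 1. For compound 3 the estimate is 35 nM, with a range from 12 nM to 110 nM.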

Compound 3, half-maximal inhibitory concentration: 2 nM
Compound 3: middle estimate off by 18-fold (1.24 log units), on the high side; the whole stated range lies above it.
By their numbers in this assay, from the lowest: compound 3; then compound 1; then compound 2.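

Compound 1 and compound 2 differed in two things at once, the ring and its amino group, and compound 3 pulls these apart. In this assay, closing the open-chain diethylamino into a 3-methylpyrrolidin-1-yl ring gives a 44-fold lower number from compound 2 to compound 3 (1.64 log units; beyond the scatter) while losing the amino group does not cost strength, since methyl in its place gives a 6.0-fold lower number from compound 1 to compound 3 (0.78 log units; beyond the scatter) and so the amino group on the ring is not required for strong displacement. No measurement shown here explains why either change acts as it does.

Going by these compounds, what a pyrrolidin-1-yl ring with no methyl at all would give stays open, so the share of the ring and the share of the methyl cannot yet be separated. On these data alone, whether a larger methyl replacement such as ethyl, a hydroxyl group, or a six-membered piperidin-1-yl ring would hold this strength also remains open.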